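Swapping 3-fluorophenyl for 4-(dimethylamino)phenyl at the assay limit

This account rests on a few compounds, and the source may have more. Where it says the series, first, only, none or still open, it means among the compounds named here.

In a functional assay on SK-OV-3 cells (Homo sapiens) for antiproliferative activity, read by MTT assay, with a stated time of 24 h (a higher number here means a weaker inhibitor, a lower number a stronger inhibitor), compound 1 `COc1ccc(C(=O)/C=C/c2cc(OC)c(OC)c(OC)c2)c2c1C=CC(C)(C)O2` gives a measured number (9700 nM). Compound 2 `COc1ccc(C(=O)/C=C/c2ccc(F)cc2)c2c1C=CC(C)(C)O2` returns only a limit (> 10000 nM). Going by these compounds, compound 3 `COc1ccc(C(=O)/C=C/c2cccc(F)c2)c2c1C=CC(C)(C)O2` also returns only a limit (> 10000 nM), so its true standing is unknown. The series thus presses against the limit of > 10000 nM in this assay, at which 2 of the 3 values shown sit, and offers little to build on. For the measured compounds named here, the one measured step (a step that the two limits leave unreadable from compound 2 to compound 3) has no readable size. Compound 4 `COc1ccc(C(=O)/C=C/c2ccc(N(C)C)cc2)c2c1C=CC(C)(C)O2` carries 4-(dimethylamino)phenyl in place of 3-fluorophenyl on a double-bonded chain carbon bound to a double-bonded chain carbon. Going by the values given here, no measured step covers this change, so only a small move towards stronger inhibition is expected. The expected step (an at least 1.2-fold lower number from compound 3 to compound 4 (0.09 log units; that floor lies within the scatter)) is loosely fixed. For compound 4 the estimate is 8000 nM with an expected range from 2500 nM to 25000 nM in this assay as well.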

Compound 4, half-maximal inhibitory concentration: 2750 nM
Compound 4: middle estimate off by 2.9-fold (0.46 log units), on the high side; low and high end bracket the measured number.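

In this assay, for the compounds shown here, 4-(dimethylamino)phenyl gives the first readable change at this position, an at least 3.6-fold lower number from compound 3 to compound 4 (0.56 log units; beyond the scatter). Read on the aromatic carbon itself, dimethylamino in place of fluoro gives an at least 3.6-fold lower number from compound 2 to compound 4 (0.56 log units; beyond the scatter). Both are floors rather than sizes, and the step between the two fluorophenyl compounds cannot be read, because compound 2 and compound 3 stand only as limits: the limit of > 10000 nM in this assay, at which 2 of the 4 values shown sit.

Going by these compounds, the true size of the change therefore stays open. So does whether a primary amine or a morpholine on the same aromatic carbon would give a similar result.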